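Replacing a guanidine group with pyridin-2-yl on a sulfonamide

This account rests on a few compounds, and the source may have more. Where it says the series, first, only, none or still open, it means among the compounds named here.

Compound 1 `Nc1ccc(S(=O)(=O)Nc2ccnc3cc(C(F)(F)F)ccc23)cc1`: 31000 nM
Compound 2 `O=C(Nc1ccccc1)Nc1ccc(S(=O)(=O)Nc2ccnc3cc(C(F)(F)F)ccc23)cc1`: 52900 nM
Compound 3 `N=C(N)NS(=O)(=O)c1ccc(N/C(S)=N\c2ccnc3cc(C(F)(F)F)ccc23)cc1`: "not active" (no number reported)

All three measured compounds share the same core and were tested in a functional assay on MDA-MB-231 cells (Homo sapiens) for antiproliferative activity, read by sulforhodamine B assay, with a stated time of 48 h; on this read-out higher numbers stand for weaker inhibition and lower numbers for stronger inhibition. Compound 1 gives 31000 nM, and compound 2 gives 52900 nM; the step of a 1.7-fold higher number from compound 1 to compound 2 (0.23 log units; within the scatter) lies within the scatter. Compound 3 stands apart from these two: in this assay compound 3 is reported as "not active" (no number reported), with no number, so it cannot be placed against compound 1 or compound 2 on the scale.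

Compound 4 `O=S(=O)(Nc1ccccn1)c1ccc(N/C(S)=N\c2ccnc3cc(C(F)(F)F)ccc23)cc1` differs from compound 3 by a group of 6 heavy atoms (5 carbon, 1 nitrogen; one six-membered aromatic ring with 1 hetero atom) in place of a group of 3 heavy atoms (1 carbon, 2 nitrogen; no ring), on a sulfonamide nitrogen. Among the compounds with values here, none of the measured steps touches this part of the molecule; the only measured step, a 1.7-fold higher number from compound 1 to compound 2 (0.23 log units; within the scatter), changes a different nitrogen and was within the scatter. Within the data shown here, there is therefore no step in the data that bears directly on the change from compound 3 to compound 4, and the two weakly active compounds 1 and 2 set the general level of this series.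

Compound 4 is expected to remain weak in this assay, with an estimate of 50000 nM, in a range from 15000 nM to 150000 nM, and a real chance that only a limit is reported.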

Compound 4, half-maximal inhibitory concentration: 49300 nM
Compound 4: middle estimate off by 1.0-fold (0.01 log units), on the high side; the measured number falls inside the stated range.
By their numbers in this assay, from the lowest: compounds 1, 4 and 2 (each within the scatter of the next).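

In this assay, within the data shown here, compound 3 is reported without a number, so no step from compound 3 to compound 4 can be read. No evidence on hand bears on this result.

The compounds shown leave open how far pyridin-2-yl on the sulfonamide nitrogen of compound 4 shifts the response relative to the group it replaces in compound 3.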